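A few compounds are considered here, and "the series" means these few. Any claim that something is new, unique, unknown or untested is made for them only; others in the source may bear on it.

Measured compounds:
compound 1, `Cc1cccc(C)c1-c1cccc(COc2ccc(S(=O)(=O)CC(=O)O)cc2)c1`: 66.1 nM
compound 2, `COc1cc(C)c(-c2cccc(COc3ccc(S(=O)(=O)CC(=O)O)cc3)c2)c(C)c1`: 57.5 nM
compound 3, `O=C(O)CS(=O)(=O)c1ccc(OCc2cccc(-c3ccccc3F)c2)cc1`: 257 nM

In a functional assay on CHO cells for agonist activity at Free fatty acid receptor 1 (Homo sapiens), read by FLIPR and calcium flux (a higher number here means that more compound is needed for the effect, a lower number that less compound is needed), compound 3 gives 257 nM, the highest of the three numbers. Its nearest neighbour is compound 1, reached by a 3.9-fold higher number from compound 1 to compound 3 (0.59 log units; beyond the scatter); the furthest is compound 2, reached by a 4.5-fold higher number from compound 2 to compound 3 (0.65 log units; beyond the scatter). Compounds 1 and 2 sit close together, as a 1.1-fold lower number from compound 1 to compound 2 (0.06 log units; within the scatter) shows.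

Compound 4, `O=C(O)CS(=O)(=O)c1ccc(OCc2cccc(-c3ccccc3Cl)c2)cc1`, differs from compound 3 in one place: chloro in place of fluoro on an aromatic carbon. Among the measured compounds shown here, none of the measured steps exchanges one halogen for another; the two steps that touch this part of the molecule, a 3.9-fold higher number from compound 1 to compound 3 (0.59 log units; beyond the scatter) and a 4.5-fold higher number from compound 2 to compound 3 (0.65 log units; beyond the scatter), replace the whole outer ring, and both are only modest in size. A swap of a single halogen is a smaller change than either, so the step to compound 4 is expected to be small, a 1.5-fold lower number from compound 3 to compound 4 (0.18 log units; within the scatter), plausibly within the scatter, with a slight lean towards a lower number. Compound 4 is therefore estimated at 170 nM in this assay, within a range of 80 nM to 400 nM.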

Compound 4, half-maximal effective concentration: 28.8 nM
Beside the measured number, compound 4's estimate is 5.9-fold (0.77 log units) above it; measured number below the stated range.
By their numbers in this assay, from the lowest: compounds 4, 2 and 1 (each within the scatter of the next, the first and the last beyond it); then compound 3.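

In this assay the atom on the outer ring, on an aromatic carbon ortho to a large group, proves to matter: chloro in place of fluoro gives an 8.9-fold lower number from compound 3 to compound 4 (0.95 log units; beyond the scatter) and so moves the number further than either earlier replacement of the whole ring. The 2-chlorophenyl group cannot be told apart from the 4-methoxy-2,6-dimethylphenyl group, with a 2.0-fold lower number from compound 2 to compound 4 (0.30 log units; within the scatter) as the step, and it improves modestly on the 2,6-dimethylphenyl group, with a 2.3-fold lower number from compound 1 to compound 4 (0.36 log units; beyond the scatter) as the step, so one chloro does at least as well here as two methyl groups. Nothing available explains why this exchange of one halogen for another has such an effect.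

Going by these compounds, how bromo, trifluoromethyl or nitrile would behave at the same place remains open. So does whether chloro combined with a methoxy group on the same outer ring would lower the number further.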